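The source may hold more compounds than are shown below. What is called first, only, known or untested is meant among the compounds shown, and "the series" means these compounds.

Compound 2 `C=CC(=O)N1C(=O)CC(c2ccc(C)cc2)Sc2ccccc21` is tested in a functional assay on MOLT-4 cells (Homo sapiens) for cytotoxicity, read by CCK-8 assay, with a stated time of 24 h (on this read-out lower numbers stand for stronger inhibition and higher numbers for weaker inhibition), where compound 2 gives 87600 nM. Compound 1 `C=CC(=O)N1C(=O)CC(c2ccc([N+](=O)[O-])cc2)Sc2ccccc21` carries a nitro where compound 2 carries a methyl; in this assay compound 1 gives 91500 nM, and a 1.0-fold lower number from compound 1 to compound 2 (0.02 log units; within the scatter), so the two compounds cannot be told apart. Compound 3 `C=CC(=O)N1C(=O)CC(c2ccccc2Cl)Sc2ccccc21` is the next structure: 2-chlorophenyl in place of 4-methylphenyl on a saturated ring carbon. Among the measured compounds shown here, the only step on record changes one substituent on that phenyl for another and hardly moved the number, so the expected 1.0-fold higher number from compound 2 to compound 3 (0.01 log units; within the scatter) is a step within the scatter. Compound 3 is therefore estimated at 90000 nM, with a range from 40000 nM to 200000 nM.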

Compound 3, half-maximal inhibitory concentration: 80300 nM
Estimate against measurement, compound 3: 1.1-fold (0.05 log units) above; measured number inside the range.
By their numbers in this assay, from the lowest: compounds 3, 2 and 1 (each within the scatter of the next).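

In this assay, the swap from 4-methylphenyl to 2-chlorophenyl gives a 1.1-fold lower number from compound 2 to compound 3 (0.04 log units; within the scatter), so compound 2 and compound 3 cannot be told apart. Unlike the earlier pair, this step alters both the substituent and where it sits on the phenyl, and the read-out still does not separate the compounds. No supporting data bear on why these numbers lie so close. From the compounds shown here alone, whether an amine or a carboxylic acid on the phenyl, or a longer chain in its place, would give a distinguishable number remains open.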